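The compounds below may be only part of what the source reports. "The series", "measured", "known", "first", "only" and "open" are said of these compounds alone.

Measured in a functional assay on PC-3 cells (Homo sapiens) for inhibition, read by MTT assay, with a stated time of 72 h; on this read-out lower numbers stand for stronger inhibition and higher numbers for weaker inhibition:
compound 1 `C=CC(=O)Nc1cccc(NC(=O)CSc2nc(Nc3ccccc3)c3ccccc3n2)c1`: 8740 nM
compound 2 `C=CC(=O)Nc1cccc(NC(=O)CSc2nc(Nc3cccc(Cl)c3)c3ccccc3n2)c1`: 12300 nM
compound 3 `C=CC(=O)Nc1cccc(NC(=O)CSc2nc(Nc3ccc(Br)cc3)c3ccccc3n2)c1`: 12400 nM

Compound 3 sits alongside the other two in this assay: the step of a 1.4-fold higher number from compound 1 to compound 3 (0.15 log units; within the scatter) and the step of a 1.0-fold higher number from compound 2 to compound 3 (0.00 log units; within the scatter) are both within the scatter, so the three numbers cannot be ordered.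

Compound 4 `C=CC(=O)Nc1cccc(NC(=O)CSc2nc(Nc3ccc(C(F)(F)F)cc3)c3ccccc3n2)c1` follows from compound 3 by trifluoromethyl in place of bromo on an aromatic carbon. Within the data shown here, no measured step carries a trifluoromethyl; the nearest cases are the substitutions on the same ring, a 1.4-fold higher number from compound 1 to compound 2 (0.15 log units; within the scatter) and a 1.4-fold higher number from compound 1 to compound 3 (0.15 log units; within the scatter), neither of which moved the number beyond the scatter. The step of a 1.0-fold lower number from compound 3 to compound 4 (0.01 log units; within the scatter) is therefore expected to stay within the scatter, with no direction claimed. Compound 4 is estimated at 12000 nM, in a range of 5000 nM to 30000 nM.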

Compound 4, half-maximal inhibitory concentration: 12500 nM
Compound 4: the middle estimate sits 1.0-fold (0.02 log units) below what was measured; the range from low to high includes it.
By their numbers in this assay, from the lowest: compounds 1, 2, 3 and 4 (each within the scatter of the next).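

In this assay, trifluoromethyl on this aromatic carbon, para to a large group, brings 4 heavy atoms where bromo has 1, yet the step stays within the scatter: a 1.0-fold higher number from compound 3 to compound 4 (0.00 log units; within the scatter). The other two steps, a 1.0-fold higher number from compound 2 to compound 4 (0.01 log units; within the scatter) and a 1.4-fold higher number from compound 1 to compound 4 (0.16 log units; within the scatter), are also within the scatter, so hydrogen, chloro, bromo and trifluoromethyl on this ring are not separated by this read-out. No supporting measurement offers an explanation for this flat result.

On these data alone, whether an amine, a carboxylic acid or a longer chain on this ring would give a step beyond the scatter remains open.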